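A few compounds are considered here, and "the series" means these few. Any claim that something is new, unique, unknown or untested is made for them only; others in the source may bear on it.

Measured compounds:
Compound 1, `CCCCCCCCc1ccc(OCC(=O)Cn2nnc(SC)n2)cc1`, gives 31 nM in an assay on microsomes from brain for inhibition of Fatty-acid amide hydrolase 1 (Rattus norvegicus), read by fluorescence and HPLC, with a stated time of 60 min; on this read-out higher numbers stand for weaker inhibition and lower numbers for stronger inhibition.
Compound 2, `CCCCCCCCc1ccc(OCC(=O)Cn2nnc(-c3cccc(Cl)c3)n2)cc1`, gives 24 nM.
Compound 3, `CCCCCCCCc1ccc(OCC(=O)Cn2nnc(-c3cccc(C(=O)OC)c3)n2)cc1`, gives 34 nM.

Compound 3 carries the highest of the three numbers, yet its neighbours sit close: compound 1 is nearer and compound 2 further, and both gaps lie within the scatter. The three compounds share one core and differ only in the group on an aromatic carbon of a five-membered aromatic ring with 4 nitrogen. Every measured step at that place stayed within the scatter: a 1.3-fold lower number from compound 1 to compound 2 (0.11 log units; within the scatter), a 1.1-fold higher number from compound 1 to compound 3 (0.04 log units; within the scatter), and a 1.4-fold higher number from compound 2 to compound 3 (0.15 log units; within the scatter).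

Compound 4, `CCCCCCCCc1ccc(OCC(=O)Cn2nnc(-c3ccccn3)n2)cc1`, is not yet measured. It differs from compound 3 in one place: pyridin-2-yl in place of 3-(methoxycarbonyl)phenyl on an aromatic carbon. Since the three measured exchanges at this position left this assay essentially unmoved, the same is expected here, with no step beyond the scatter in either direction. The expected step is a 1.1-fold lower number from compound 3 to compound 4 (0.05 log units; within the scatter). Compound 4 is therefore estimated at 30 nM, with a range from 12 nM to 75 nM.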

Compound 4, half-maximal inhibitory concentration: 18 nM
Compound 4: middle estimate off by 1.7-fold (0.22 log units), on the high side; the measured number falls inside the stated range.
By their numbers in this assay, from the lowest: compounds 4, 2, 1 and 3 (each within the scatter of the next).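

Across the four compounds, pyridin-2-yl brings the first ring nitrogen to this place, on an aromatic carbon of a five-membered aromatic ring with 4 nitrogen, and this assay still gives only small steps: (a 1.9-fold lower number from compound 3 to compound 4 (0.28 log units; within the scatter)), (a 1.3-fold lower number from compound 2 to compound 4 (0.12 log units; within the scatter)) and (a 1.7-fold lower number from compound 1 to compound 4 (0.24 log units; within the scatter)), each within the scatter. The place therefore accepts a six-membered aromatic ring with a hetero atom and no further group on it, just as it accepts methylsulfanyl and the substituted phenyl rings, so none of the four groups stands apart in this assay. Nothing available explains why the number stays so flat at this place.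

On these data alone, whether a pyridin-3-yl ring, a free carboxylic acid in place of the methyl ester, or an amine would give a step beyond the scatter remains open. So does whether a long alkyl chain at this place would leave the number as unmoved as these four groups do.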